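From 2-hydroxyethyl to 3-hydroxypropyl on the shared core

This account rests on a few compounds, and the source may have more. Where it says the series, first, only, none or still open, it means among the compounds named here.

Compound 1 `CNC(=O)CCCn1c2ccc([N+](=O)[O-])cc2c(=O)n1Cc1ccccc1`: > 256000 nM
Compound 2 `O=c1c2cc([N+](=O)[O-])ccc2n(CCO)n1Cc1ccccc1`: > 256000 nM

Both entries come from an ADME assay on L929 cells (Mus musculus) for cytotoxicity, read by resazurin assay, with a stated time of 48 h (on this read-out higher numbers stand for lower toxicity in this test and lower numbers for higher toxicity in this test), and each is a limit of the assay rather than a number. Compound 2 stands at > 256000 nM, which is a limit. The whole record so far is the limit of > 256000 nM in this assay, at which 2 of the 2 values shown sit. Within the data shown here, the only measured step is a step that the two limits leave unreadable from compound 1 to compound 2, with hydroxy in place of (methylcarbamoyl)methyl on the chain, and it offers no size to carry forward.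

Compound 3 `O=c1c2cc([N+](=O)[O-])ccc2n(CCCO)n1Cc1ccccc1` differs from compound 2 by hydroxymethyl in place of hydroxy on a saturated chain carbon, two bonds along the chain from an aromatic nitrogen. In other words, 2-hydroxyethyl becomes 3-hydroxypropyl.

Since compound 2 reads > 256000 nM, no step beyond the scatter is expected in either direction in this assay, and another limit is the likeliest report. The expected step is a number no higher from compound 2 to compound 3 (the limit leaves the size open). The estimated value for compound 3 is 256000 nM, within an expected range from 128000 nM to 512000 nM.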

Compound 3, concentration lethal to 50% of the cells: > 256000 nM
Compound 3: a limit, no number (the forecaster's own chance of this, stated with the estimate: 85%); the middle value sits exactly at the limit.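

No new step can be read among compound 1, compound 2 and compound 3, since each entry is a limit and not a number: the limit of > 256000 nM in this assay, at which 3 of the 3 values shown sit.

The compounds shown leave open how far apart these three truly lie, and whether any other chain on the shared core would give a readable number at all.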